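Cytotoxicity notes: one group rearranged on the shared core

A few compounds are considered here, and "the series" means these few. Any claim that something is new, unique, unknown or untested is made for them only; others in the source may bear on it.

In an ADME assay on HMEC cells (Homo sapiens) for cytotoxicity, read by MTT assay (on this read-out higher numbers stand for weaker inhibition and lower numbers for stronger inhibition), compound 1 (`Nc1nc(NCc2ccc(C(=O)Nc3ccccc3N)cc2)nc(NC2CCCC2)n1`) gives 11000 nM and compound 2 (`Nc1nc(NCc2ccc(C(=O)Nc3ccccc3N)cc2)nc(N2CCc3ccccc32)n1`) gives 10000 nM. For the measured compounds named here, these are the only two numbers so far, and they lie within the scatter of each other, so compound 2 stands level with compound 1.

Compound 3 (`Nc1nc(NCc2ccc(C(=O)Nc3ccccc3N)cc2)nc(N2Cc3ccccc3C2)n1`) keeps the shared core and differs from compound 2 only in one group: a group of 9 heavy atoms (8 carbon, 1 nitrogen; one five-membered non-aromatic ring with 1 hetero atom, one six-membered aromatic ring of carbon only) in place of a group of 9 heavy atoms (8 carbon, 1 nitrogen; one five-membered non-aromatic ring with 1 hetero atom, one six-membered aromatic ring of carbon only), on an aromatic carbon. The 2,3-dihydro-1H-indol-1-yl group leaves and a group with no common name enters, made of the same atoms joined differently.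

Going by the values given here, one measured step bears on this: a 1.1-fold lower number from compound 1 to compound 2 (0.04 log units; within the scatter). That step brought in 2,3-dihydro-1H-indol-1-yl in place of cyclopentylamino at the same place and stayed within the scatter. Among the compounds with values here, it is a single step, and no measured compound carries the entering group, so the range is kept wide.

The expected change is no more than scatter, and the estimated size is no change at the digits printed from compound 2 to compound 3 (within the scatter). In this assay the estimate for compound 3 is 10000 nM, with an expected range from 5000 nM to 20000 nM.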

Compound 3, half-maximal inhibitory concentration: > 50000 nM
Compound 3: a limit, no number (the forecaster's own chance of this, stated with the estimate: 10%); at least 5.0-fold (0.69 log units) between middle value and limit.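

In this assay, this position on the aromatic carbon between two ring nitrogen atoms proves sensitive to how the same atoms are joined: the new arrangement gives an at least 5.0-fold higher number from compound 2 to compound 3 (0.69 log units; beyond the scatter), whereas the earlier replacement of cyclopentylamino by 2,3-dihydro-1H-indol-1-yl gave a 1.1-fold lower number from compound 1 to compound 2 (0.04 log units; within the scatter). Measured against cyclopentylamino, the entering group gives an at least 4.5-fold higher number from compound 1 to compound 3 (0.65 log units; beyond the scatter), so the shift appears from both neighbouring compounds, and the leaving and entering groups of compounds 2 and 3 match in every count of atoms, donors and acceptors. Compound 3 carries a limit and not a number, so the full size of both steps remains unknown: the limit of > 50000 nM in this assay, at which 1 of the 3 values shown sits.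

Still open, on these data alone, is whether the higher number belongs to this particular joining of atoms alone or would also come with other groups at this place, such as piperidine, morpholine or dimethylamino. Three compounds support no rule beyond themselves, and nothing shown says whether the same change would behave alike on a different core.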